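The compounds below may be only part of what the source reports. "The series", "measured", "known", "first", "only" and "open" are said of these compounds alone.

Compound 2, `O=C(c1ccccc1)c1cccc(NC(=O)C2CCCN(C(=O)c3cc(C(F)(F)F)cc(C(F)(F)F)c3)C2)c1`, is one of two analogues carrying the shared core, and in an ADME assay on PC-3 cells (Homo sapiens) for cytotoxicity, read by WST assay, tested at 100 uM (on this read-out higher numbers stand for more inhibition at the one concentration tested (going by the name of the read-out) and lower numbers for less inhibition), compound 2 gives 0%. Within the data shown here, its only measured neighbour is compound 1, `CC(=O)c1cccc(NC(=O)C2CCCN(C(=O)c3cc(C(F)(F)F)cc(C(F)(F)F)c3)C2)c1`, which in this assay gives 0%. Among the measured compounds shown here, the one step between them, no change at the digits printed from compound 1 to compound 2 (within the scatter), shows that exchanging a methyl for a phenyl on the carbonyl carbon left the read-out unmoved. Compound 2 therefore stands level with compound 1 at the digits shown, both sitting at the floor of the read-out.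

Compound 3, `COc1cccc(NC(=O)C2CCCN(C(=O)c3cc(C(F)(F)F)cc(C(F)(F)F)c3)C2)c1`, has not yet been measured in this assay. It differs from compound 2 in a single place: methoxy in place of benzoyl on an aromatic carbon. For the measured compounds named here, the only step that bears on this change is the one from compound 1 to compound 2, where swapping the group on the carbonyl carbon made no difference within the scatter, so nothing among the measured compounds suggests that the substituent on this aromatic carbon moves the read-out. On that basis compound 3 is expected to give 0%, within a range of -10% to 10%, which amounts to an estimated step of no change at the digits printed from compound 2 to compound 3 (within the scatter) from compound 2.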

Compound 3, a percentage reported as inhibition, at one concentration (the size of the read-out at that concentration, not a potency): 0%
Compound 3: middle estimate and measured number agree at the digits printed, within the range that was stated.
By their numbers in this assay, from the lowest: compounds 1, 2 and 3 (each within the scatter of the next).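

In this assay, the earlier pair changed only the group on a carbonyl carbon, while this change replaces the whole benzoyl on the aromatic carbon, meta to a large group, with methoxy, and the result is no change at the digits printed from compound 2 to compound 3 (within the scatter). The comparison with the acetyl compound gives the same picture, with no change at the digits printed from compound 1 to compound 3 (within the scatter), so three groups at this one position, with and without a carbonyl and with and without a six-membered aromatic ring, now share the same read-out. No measurement is available that would explain this lack of movement.

With all three compounds on the same value, the series has yet to show any group at this position that moves the number, and it leaves open whether an amine, a carboxylic acid or a longer chain such as butoxy on this aromatic carbon would do so. It also leaves open whether replacing a trifluoromethyl group elsewhere on the shared core, for instance with a chlorine atom, would change the read-out in this assay.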